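The source may report more compounds than this note shows. Statements on the series, on what has been measured and on what is new or still open speak of the compounds shown alone.

Measured so far:
compound 1, `Nc1nc(NCc2ccccc2)nc(-c2ccccc2CO)n1`, 4.35
compound 2, `Nc1nc(NCc2ccc(Cl)cc2)nc(-c2ccccc2CO)n1`, 5.22
compound 3, `Nc1nc(NCc2ccc(C(F)(F)F)cc2)nc(-c2ccccc2CO)n1`, 5.03

In a functional assay on cells for positive allosteric modulation of G-protein coupled receptor 68 (Homo sapiens), read by a luciferase reporter and cAMP accumulation, with a stated time of 30 min, at pH 6.8 and pH 8.3, in the presence of a further agent that is not named here (a higher number here means a more potent compound, by a factor of ten per unit of this negative logarithm, a lower number a less potent compound), compound 2 gives the highest of the three numbers; compound 3 lies within the scatter of it, compound 1 lies clearly lower. Compound 4, `COc1cccc(CNc2nc(N)nc(-c3ccccc3CO)n2)c1`, has not been measured. It differs from compound 2 by 3-methoxyphenyl in place of 4-chlorophenyl on a saturated chain carbon bound to a nitrogen on an aromatic ring. Among the compounds with values here, two measured steps bear on this change. The step of a number 0.87 log units higher from compound 1 to compound 2 (beyond the scatter) shows what chloro added to the unsubstituted ring of compound 1 brought, and a number 0.19 log units lower from compound 2 to compound 3 (within the scatter) shows that trifluoromethyl in its place changes little. Within the data shown here, no measured compound carries a methoxy group, so its effect is unknown. Losing the chloro is therefore expected to cost most of that gain, leaving compound 4 near compound 1: an estimated 4.6, range 4.1 to 5.2, a step of a number 0.62 log units lower from compound 2 to compound 4 (beyond the scatter).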

Compound 4, negative logarithm of the antagonist equilibrium constant: 4.11
Estimate against measurement, compound 4: 0.49 log units above, within the range that was stated.
By their numbers in this assay, from the lowest: compounds 4 and 1 (each within the scatter of the next); then compounds 3 and 2 (each within the scatter of the next).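

Replacing 4-chlorophenyl with 3-methoxyphenyl at this saturated chain carbon gives the largest step in the series, a number 1.11 log units lower from compound 2 to compound 4 (beyond the scatter), while the methoxy group leaves the number close to that of the unsubstituted ring, a number 0.24 log units lower from compound 1 to compound 4 (within the scatter). So, unlike chloro and trifluoromethyl, this group at this ring position brings no gain that can be read. No measurement available here accounts for the difference. Compound 4 changes both the group and its place on the ring, so the two effects remain unseparated. A 4-methoxyphenyl or 3-chlorophenyl group would tell them apart.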